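Swapping methoxy for acetyl on a xanthine side chain

This account rests on a few compounds, and the source may have more. Where it says the series, first, only, none or still open, it means among the compounds named here.

Measured compounds:
- Compound 1, `Cn1c(=O)n(Cc2ccccc2)c(=O)c2[nH]cnc21`: 10200 nM
- Compound 2, `CC(=O)OCCn1cnc2c1c(=O)n(C)c(=O)n2C`: 23200 nM
- Compound 3, `COCn1c(=O)c2c(ncn2C)n(C)c1=O`: 14000 nM

All three were tested in an assay on HEK293 cells for binding affinity to adenosine receptor A2b (Homo sapiens), read by radioligand binding; a lower number here means a stronger inhibitor, a higher number a weaker inhibitor. Compound 1 gives 10200 nM, compound 2 gives 23200 nM and compound 3 gives 14000 nM. The number for compound 3 lies between those of compound 1 and compound 2, and the gap to each of them is within the scatter, so the three values cannot be told apart with confidence. Nothing here separates any one compound from the others.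

Compound 4, `CC(=O)Cn1c(=O)c2c(ncn2C)n(C)c1=O`, has not been measured yet. Compared with compound 3 the change is acetyl in place of methoxy on a saturated chain carbon bound to an aromatic nitrogen. The shared core and the methyl groups on it stay as they are; only the end of the short chain on the ring nitrogen is exchanged.

Among the measured compounds shown here, no pair of measured compounds differs in one place, so no measured step can guide this one. The three measured values sit close together despite different side chains, which gives no reason to expect a move beyond the scatter in this assay. The step from compound 3 to compound 4 is therefore estimated as a 1.1-fold higher number from compound 3 to compound 4 (0.03 log units; within the scatter), in no firm direction.

Compound 4 is expected to give about 15000 nM, with a range from 5000 nM to 45000 nM.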

Compound 4, inhibition constant: 20800 nM
Compound 4: middle estimate off by 1.4-fold (0.14 log units), on the low side, and the stated range covers the measured number.
By their numbers in this assay, from the lowest: compounds 1, 3, 4 and 2 (each within the scatter of the next, the first and the last beyond it).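

In this assay, the exchange of methoxy for acetyl on a saturated chain carbon bound to an aromatic nitrogen amounts to a 1.5-fold higher number from compound 3 to compound 4 (0.17 log units; within the scatter). Among the compounds shown here, this is the first direct comparison in the set, since the earlier compounds differ from one another in more than one place and could only suggest that the side chain matters little. The pair now shows that, on this shared core, methoxymethyl and 2-oxopropyl cannot be told apart in this measurement, even though acetyl brings a double bond outside aromatic rings that methoxy lacks, and no accompanying data bear on this result.

For the compounds shown here, a single step within the scatter covers only this one exchange, and it leaves open whether a primary amine, a carboxylic acid or a longer chain such as 3-oxobutyl at the same place would give a number that differs beyond the scatter. It also leaves open whether the same exchange of methoxy for acetyl would be equally silent on a different core or with other groups on the shared core.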